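Trimming a Methyl from a Dinitrile Thiazole

This account rests on a few compounds, and the source may have more. Where it says the series, first, only, none or still open, it means among the compounds named here.

Compound 1, `CC(c1nccs1)C(C#N)(C#N)CCC(F)=C(F)F`, was tested in a functional assay on MCF7 cells (Homo sapiens) for cytotoxicity, read by MTT assay, with a stated time of 48 h; a lower number here means a stronger inhibitor, a higher number a weaker inhibitor. In this assay compound 1 gives > 120000 nM, which is a limit of the assay and not a number. Compound 2, `O=S(=O)(CCC(F)=C(F)F)c1nc2ccc(OC(F)F)cc2[nH]1`, belongs to the same set. In this assay compound 2 gives > 120000 nM, again a limit of the assay rather than a number. Among the compounds with values here, compound 1 therefore stands nowhere on a scale of numbers: the two values shown both sit at the limit of > 120000 nM in this assay, at which 2 of the 2 values shown sit, and no step between measured compounds can be read from them.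

Compound 3, `N#CC(C#N)(CCC(F)=C(F)F)Cc1nccs1`, has not yet been measured in this assay. It differs from compound 1 by hydrogen in place of methyl on a saturated chain carbon bound to an aromatic carbon and a saturated chain carbon. Within the data shown here, since both measured values sit at the limit of > 120000 nM in this assay, at which 2 of the 2 values shown sit, there is no measured step on which to build, and the change removes only a methyl. The step is expected to be a step that the limit leaves unreadable from compound 1 to compound 3, nothing beyond the scatter. Compound 3 is therefore estimated at about 150000 nM, with a range from 60000 nM to 400000 nM, and is expected most likely to be reported as a limit as well.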

Compound 3, half-maximal inhibitory concentration: > 120000 nM
Compound 3 ended at the assay's limit (the forecaster's own chance of this, stated with the estimate: 85%); the middle value does not contradict the limit.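

Within the data shown here, no step from compound 1 to compound 3 can be read in this assay, because both compounds sit at a limit of the assay and not at a number: the limit of > 120000 nM in this assay, at which 3 of the 3 values shown sit. The compounds shown leave open how they would rank against one another and whether hydrogen in place of methyl changes the read-out at all.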